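The compounds below may be only part of what the source reports. "The series", "measured", "known", "first", "only" and "open" are said of these compounds alone.

Measured in a functional assay on HL-60 cells (Homo sapiens) for cytotoxicity, read by WST assay, with a stated time of 48 h; a higher number here means that more compound is needed for the effect, a lower number that less compound is needed:
- compound 1 `Cc1ccccc1C[C@H]1C(=O)OC[C@@H]1Cc1ccccc1`: 57000 nM
- compound 2 `CCCCCCCOc1ccc(C[C@H]2C(=O)OC[C@@H]2Cc2ccccc2)cc1`: > 100000 nM
- compound 3 `O=C1OC[C@H](Cc2cccc(O)c2)[C@H]1Cc1ccc(Cl)c(Cl)c1`: 48000 nM

The entry for compound 2 is a limit of the assay, not a number. Compound 3 stands level with compound 1, as their two values lie within the usual scatter of each other.

Compound 4 `CCc1ccc(C[C@H]2COC(=O)[C@@H]2Cc2ccc(Cl)c(Cl)c2)cc1` has not yet been measured. It carries 4-ethylphenyl in place of 3-hydroxyphenyl on a saturated chain carbon bound to a saturated ring carbon.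

For the measured compounds named here, no measured pair here differs in just one place, so the data give no direct size for such a change. The expected shift in this assay is none beyond the scatter, shown as a 1.1-fold lower number from compound 3 to compound 4 (0.03 log units; within the scatter). For compound 4 the estimate is 45000 nM, with an expected range of 15000 nM to 100000 nM.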

Compound 4, half-maximal effective concentration: 16000 nM
Beside the measured number, compound 4's estimate is 2.8-fold (0.45 log units) above it; the measured number falls inside the stated range.
By their numbers in this assay, from the lowest: compound 4; then compounds 3 and 1 (each within the scatter of the next). At a limit, above all of these: compound 2.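

In this assay, for the compounds shown here, putting 4-ethylphenyl in place of 3-hydroxyphenyl on a saturated chain carbon bound to a saturated ring carbon gives a 3.0-fold lower number from compound 3 to compound 4 (0.48 log units; beyond the scatter), the first measured step at a single place in this set. It shows that the number responds to what sits at this position, and that compound 4 needs no hydroxyl group to reach its value. Nothing shown here explains the step.

This single step cannot separate losing the hydroxyl group from adding the ethyl group. As far as these compounds go, how an amine or a carboxylic acid on this phenyl ring would compare remains open.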